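A few compounds are considered here, and "the series" means these few. Any claim that something is new, unique, unknown or untested is made for them only; others in the source may bear on it.

Compound 1 `O=C(CCCCCONC(=O)Nc1ccc2ccccc2c1)NO` gives 1400 nM
Compound 2 `COc1cc(NC(=O)NOCCCCCC(=O)NO)c2ncccc2c1` gives 1200 nM
Compound 3 `COc1cc(NC(=O)NOCCCCCC(=O)NO)c2nccc(C)c2c1` gives 1100 nM

All three values come from a functional assay on A2780 cells (Homo sapiens) for antiproliferative activity, read by MTT assay, with a stated time of 72 h (a higher number here means a weaker inhibitor, a lower number a stronger inhibitor), and lie within the scatter of one another, so compound 3 cannot be ranked apart from compound 1 or compound 2. Compound 4 `COc1cc(NC(=O)NOCCCCCC(=O)NO)c2nc(OC)cc(C)c2c1` differs from compound 3 by one change, methoxy in place of hydrogen on an aromatic carbon with methoxy in place of hydrogen on an aromatic carbon. Within the data shown here, the one measured step that bears on this is a 1.1-fold lower number from compound 2 to compound 3 (0.04 log units; within the scatter) for methyl in place of hydrogen on an aromatic carbon. That step involves a different group, so it offers only weak guidance, and no step beyond the scatter is expected in this assay in either direction. The expected step is a 1.1-fold lower number from compound 3 to compound 4 (0.04 log units; within the scatter) and would remain within the scatter. Compound 4 is estimated at 1000 nM with an expected range from 450 nM to 2300 nM pending measurement.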

Compound 4, half-maximal inhibitory concentration: 800 nM
The estimate for compound 4 lay 1.3-fold (0.10 log units) above the measured number; measured number inside the range.
By their numbers in this assay, from the lowest: compounds 4, 3, 2 and 1 (each within the scatter of the next).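

In this assay, methoxy in place of hydrogen on the aromatic carbon next to the ring nitrogen gives a step that stays within the scatter (a 1.4-fold lower number from compound 3 to compound 4 (0.14 log units; within the scatter)). This position therefore carries methoxy alongside the methyl group of compound 3 with no step beyond the scatter, although the change adds a hydrogen-bond acceptor. No measurement on hand explains the step. The compounds shown leave open whether an amine or a carboxylic acid on this same carbon would give a step beyond the scatter.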